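The source may hold more compounds than are shown below. What is called first, only, known or untested is meant among the compounds shown, and "the series" means these compounds.

The three measured compounds share one core and differ in two places. Compound 1 `COc1ccccc1Nc1nnc(Nc2nc(-c3ccc(Br)cc3)cs2)s1` gives 300 mg/kg in a functional assay on the whole organism (strain albino) with Mus musculus as the target, in the maximal electroshock model, with a stated time of 0.5 h; a higher number here means that more compound is needed for the effect, a lower number that less compound is needed. Compound 2 `COc1ccc(Nc2nnc(Nc3nc(-c4ccc(Br)cc4)cs3)s2)cc1` gives 30 mg/kg in this assay; the change from compound 1 to compound 2 is 4-methoxyphenyl in place of 2-methoxyphenyl on a nitrogen on an aromatic ring, and it brought a 10-fold lower number from compound 1 to compound 2 (1.00 log units; beyond the scatter). Compound 3 `COc1ccccc1Nc1nnc(Nc2nc(-c3ccc([N+](=O)[O-])cc3)cs2)s1` gives 300 mg/kg in this assay. Its core differs from that of compound 1 by nitro in place of bromo on an aromatic carbon, a change that gave no change at the digits printed from compound 1 to compound 3 (within the scatter), so compound 3 stands level with compound 1 at the digits read. Compound 4 `COc1ccc(Nc2nnc(Nc3nc(-c4ccc([N+](=O)[O-])cc4)cs3)s2)cc1` has not yet been measured in this assay. It differs from compound 3 by 4-methoxyphenyl in place of 2-methoxyphenyl on a nitrogen on an aromatic ring, the same change that separates compound 2 from compound 1. Among the measured compounds shown here, with the measured step being a 10-fold lower number from compound 1 to compound 2 (1.00 log units; beyond the scatter), the step from compound 3 to compound 4 is expected to be a 10-fold lower number from compound 3 to compound 4 (1.00 log units; beyond the scatter), because a 10-fold lower number from compound 1 to compound 2 (1.00 log units; beyond the scatter) is the only measured instance of this change and the two cores differ only by nitro in place of bromo on an aromatic carbon, a change that left the number unmoved. On that basis compound 4 is estimated at 30 mg/kg, with a range from 10 mg/kg to 100 mg/kg.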

Compound 4, minimum effective dose: 30 mg/kg
The estimate for compound 4 equals the measured number at the digits printed; the range from low to high includes it.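

In this assay, 4-methoxyphenyl in place of 2-methoxyphenyl on the core that carries nitro gave a 10-fold lower number from compound 3 to compound 4 (1.00 log units; beyond the scatter), which matches what the same change did on the core that carries bromo: the same change on two cores in this assay, a 10-fold lower number (1.00 log units; beyond the scatter) from compound 1 to compound 2 and a 10-fold lower number (1.00 log units; beyond the scatter) from compound 3 to compound 4, 1.0-fold (0.00 log units) apart, within the scatter of two such steps. Nitro in place of bromo gave no change at the digits printed from compound 2 to compound 4 (within the scatter) with 4-methoxyphenyl on the nitrogen, just as it left the number unmoved with 2-methoxyphenyl: the same change on two cores in this assay, no change at the digits printed (within the scatter) from compound 1 to compound 3 and no change at the digits printed (within the scatter) from compound 2 to compound 4, 1.0-fold (0.00 log units) apart, within the scatter of two such steps. Within these four compounds, the methoxyphenyl change therefore carried from one core to the other at the same size, but this rests on only two pairs and does not show that it would carry to a core with any other group, nor why the 4-methoxyphenyl compounds need less compound.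

On these data alone, it remains open what an unsubstituted phenyl on the nitrogen, or a hydroxy or ethoxy group in place of the methoxy, would do to the number. As far as these compounds go, it is equally open whether an amine or a carboxylic acid in place of bromo or nitro would also leave the number unmoved.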